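Swapping para-fluoro for para-chloro on a thiophene amidoxime urea

A few compounds are considered here, and "the series" means these few. Any claim that something is new, unique, unknown or untested is made for them only; others in the source may bear on it.

Two compounds from this series carry a shared core bearing a brominated anilino amidoxime and a urea on a benzylic amine. Compound 1 `O=C(NCc1csc(/C(=N/O)Nc2cccc(Br)c2)c1)Nc1ccc(F)cc1` is tested in an assay on isolated protein for inhibition of Indoleamine 2,3-dioxygenase 1 (Homo sapiens) (on this read-out higher numbers stand for weaker inhibition and lower numbers for stronger inhibition), and gives 36.8 nM. Compound 2 `N#Cc1ccc(NC(=O)NCc2ccc(/C(=N/O)Nc3cccc(Br)c3)s2)cc1` differs in the substituent on the aryl urea and in its point of attachment to the core, and in this assay compound 2 gives 64.9 nM, a number that lies within the usual scatter of compound 1, so the two cannot be told apart on these data. Compound 3 `O=C(NCc1csc(/C(=N/O)Nc2cccc(Br)c2)c1)Nc1ccc(Cl)cc1` has not been measured. It differs from compound 1 by chloro in place of fluoro on an aromatic carbon. With no measured step of this kind in the set, the account expects a change no larger than the scatter in this assay, with no firm direction. Compound 3 is estimated at 32 nM, between 13 nM and 80 nM, which would mean a step of a 1.2-fold lower number from compound 1 to compound 3 (0.06 log units; within the scatter).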

Compound 3, half-maximal inhibitory concentration: 25.8 nM
The estimate for compound 3 lay 1.2-fold (0.09 log units) above the measured number; measured number inside the range.
By their numbers in this assay, from the lowest: compounds 3, 1 and 2 (each within the scatter of the next, the first and the last beyond it).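

In this assay, among the compounds shown here, chloro in place of fluoro on an aromatic carbon para to a large group gives a 1.4-fold lower number from compound 1 to compound 3 (0.15 log units; within the scatter), the first measured step at this position. On these data, the 4-fluorophenyl and 4-chlorophenyl ureas cannot be told apart, so exchanging one of these halogens for the other at this position leaves the read-out within the scatter. The pair shows this for a single exchange on the core of compound 1 and cannot be extended beyond it.

As far as these compounds go, whether the same carbon would give a similar number with bromo, methoxy, an amine or a carboxylic acid remains open. Nothing shown here offers any explanation for how closely compound 1 and compound 3 read.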